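Phenoxy in Place of Methoxy on a Shared Core

The source may hold more compounds than are shown below. What is called first, only, known or untested is meant among the compounds shown, and "the series" means these compounds.

Of the compounds shown here, three on a shared core have been measured in a functional assay on PANC-1 cells (Homo sapiens) for cytotoxicity, read by MTT assay, with a stated time of 72 h; a higher number here means a weaker inhibitor, a lower number a stronger inhibitor. Compound 1 `COc1ccc(NC2=CC(=O)c3ncncc3C2=O)cc1` gives 800 nM. Compound 2 `COc1cc(NC2=CC(=O)c3ncncc3C2=O)cc(OC)c1OC` gives 800 nM, and compound 3 `COc1ccc(NC2=CC(=O)c3ncncc3C2=O)cc1OC` gives 900 nM. Compound 1 thus stands level with compound 2 at the digits shown, the pair together at the bottom of the three numbers, while the step of a 1.1-fold higher number from compound 1 to compound 3 (0.05 log units; within the scatter) is within the scatter, as is a 1.1-fold higher number from compound 2 to compound 3 (0.05 log units; within the scatter). Compound 4 `O=C1C(Nc2ccc(Oc3ccccc3)cc2)=CC(=O)c2ncncc21` differs from compound 1 by phenyl in place of methyl on an oxygen on an aromatic ring. Among the measured compounds shown here, no measured step covers this change directly; the two recorded steps each add or remove a methoxy on the aromatic ring and both stayed within the scatter, which gives no sign that a change on that ring moves the number in this assay by much. Compound 4 is therefore expected to give 900 nM, with a range from 350 nM to 2500 nM. The step from compound 1 to compound 4 is expected to be a 1.1-fold higher number from compound 1 to compound 4 (0.05 log units; within the scatter), no change beyond the scatter.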

Compound 4, half-maximal inhibitory concentration: 1800 nM
Compound 4: middle estimate off by 2.0-fold (0.30 log units), on the low side; the range from low to high includes it.
By their numbers in this assay, from the lowest: compounds 1, 2, 3 and 4 (each within the scatter of the next, the first and the last beyond it).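

In this assay, phenyl in place of methyl on an oxygen on an aromatic ring gives a 2.3-fold higher number from compound 1 to compound 4 (0.35 log units; beyond the scatter) and so counts as a modest loss. Among the compounds shown here, the two earlier steps, which added or removed a methoxy on the same ring, stayed within the scatter, so this is the first sign that the ring does not tolerate every change equally. The group on that oxygen can move the number, at least when methyl gives way to phenyl, and no measurement shown here gives a reason for the step.

With phenyl and methyl the only groups shown on that oxygen, this single step sets no trend. Going by these compounds, it remains open whether an ethoxy, a benzyloxy, a hydroxyl or an amine in the same place would stay level with compound 1 or follow compound 4.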